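Ethyl on the Amide Nitrogen: Expecting Compound 4

This account rests on a few compounds, and the source may have more. Where it says the series, first, only, none or still open, it means among the compounds named here.

Measured compounds:
compound 1 `COc1cc(C(N)=O)nn1-c1ccccc1` gives 34.3%
compound 2 `COc1cc(C(=O)N(C)c2ccc(C)cc2)nn1-c1ccccc1` gives 22.3%
compound 3 `CCCCOc1cc(C(N)=O)nn1-c1ccccc1` gives 26.5%

These values come from a functional assay on the whole organism (strain Wistar) for inhibition, with Rattus norvegicus as the target, read by paw edema, with stated times of 30 min and 3 h, at a dose of 100 mg/kg by the oral route; a higher number here means more inhibition at the dose given (going by the name of the read-out), a lower number less inhibition. Compound 3 lies within the scatter of both compound 1 and compound 2, so no order among the three can be read. For the measured compounds named here, the only single-place step, a number 7.8 percentage points lower from compound 1 to compound 3 (within the scatter), changes the ether chain and not the amide, so it does not bear on the change at hand. Compound 4 `CCCCOc1cc(C(=O)NCC)nn1-c1ccccc1` differs from compound 3 by ethyl in place of hydrogen on an amide-type nitrogen. Going by the values given here, no measured step alters the amide-type nitrogen alone; compound 2 carries a substituted amide but differs from compound 1 in more than one place, and its value sits within the scatter of compound 1. Therefore no step beyond the scatter is expected, and compound 4 is estimated at 25%, with a range from 12% to 38%. The expected step of a number 1.5 percentage points lower from compound 3 to compound 4 (within the scatter) is small.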

Compound 4, a percentage reported as inhibition, in the whole organism at one dose (the size of the read-out at that dose, not a potency): 0%
Compound 4: the middle estimate sits 25 percentage points above what was measured; measured number outside the range, below it.
By their numbers in this assay, from the lowest: compound 4; then compounds 2, 3 and 1 (each within the scatter of the next, the first and the last beyond it).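

Ethyl in place of hydrogen on the amide-type nitrogen gives a number 26.5 percentage points lower from compound 3 to compound 4 (beyond the scatter) in this assay, the only single-place step here beyond the scatter. For the compounds shown here, this shows that the amide-type nitrogen, which no earlier single-place step touched, is a place where a change of just this size can matter at this dose. The data at hand do not say why.

From the compounds shown here alone, whether the same ethyl has this effect with the shorter ether chain of compound 1 remains open. So does what a propyl chain on this nitrogen, or a carboxylic acid in place of the amide, would give.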